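Swapping a dimethoxyphenyl for a chlorophenyl on the enamine nitrogen

The source may hold more compounds than are shown below. What is called first, only, known or untested is meant among the compounds shown, and "the series" means these compounds.

Measured compounds:
compound 1 `O=C(/C=C\Nc1ccc(F)cc1)c1nc(-c2ccc(F)cc2)n2ccccc12`: 13200 nM
compound 2 `COc1ccc(N/C=C\C(=O)c2nc(-c3ccc(C(F)(F)F)cc3)n3ccccc23)cc1OC`: > 30000 nM
compound 3 `COc1ccc(N/C=C\C(=O)c2nc(-c3ccc(OC)cc3)n3ccccc23)cc1`: "not determined" (no result reported)

In a functional assay on A549 cells (Homo sapiens) for cytotoxicity, read by MTT assay, with a stated time of 48 h (on this read-out lower numbers stand for stronger inhibition and higher numbers for weaker inhibition), compound 1 gives 13200 nM. In this assay compound 2 returns only a limit, > 30000 nM. Compound 3 has no reported result. Compound 2 therefore stands at the limit of > 30000 nM in this assay, at which 1 of the 3 values shown sits, so its true value is not known beyond that limit. Compound 4 `O=C(/C=C\Nc1ccc(Cl)cc1)c1nc(-c2ccc(C(F)(F)F)cc2)n2ccccc12` is built from compound 2 by 4-chlorophenyl in place of 3,4-dimethoxyphenyl on an amine nitrogen. Going by the values given here, no two measured compounds differ in just one place, so the size of this change has not been seen directly. Compound 4 is expected to gain somewhat, a step of an at least 1.5-fold lower number from compound 2 to compound 4 (0.17 log units; that floor lies within the scatter), though a limit may again be all that is reported. The estimate for compound 4 is 20000 nM, with a range from 6000 nM to 60000 nM.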

Compound 4, half-maximal inhibitory concentration: 18500 nM
Compound 4: the middle estimate sits 1.1-fold (0.03 log units) above what was measured, and the stated range covers the measured number.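

Putting 4-chlorophenyl in place of 3,4-dimethoxyphenyl on the amine nitrogen turns a result without a single number into a measured one in this assay, with an at least 1.6-fold lower number from compound 2 to compound 4 (0.20 log units; that floor lies within the scatter). This is the first direct view of a single change at this position, but its true size stays unknown, since compound 2 is known only as a limit: the limit of > 30000 nM in this assay, at which 1 of the 4 values shown sits.

Still open, from the compounds shown here alone, is how an unsubstituted phenyl or a pyridine ring on this nitrogen would read. Also open, going by these compounds, is whether this step would hold if a carboxylic acid replaced the trifluoromethyl group.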